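Chloro for Methyl: Expecting Compound 3 in Paw Edema

The source may hold more compounds than are shown below. What is called first, only, known or untested is meant among the compounds shown, and "the series" means these compounds.

Compound 1 `CSc1nn(-c2ccc([N+](=O)[O-])cc2)c2nc(Nc3ccccc3)n(-c3ccccc3)c(=O)c12` gives 26.6% in a functional assay on the whole organism (strain Wistar albino) for inhibition, with Rattus norvegicus as the target, read by paw edema, with a stated time of 3 h, at a dose of 25 mg/kg by the oral route; on this read-out lower numbers stand for less inhibition and higher numbers for more inhibition at the one dose given (going by the name of the read-out).
Compound 2 `Cc1ccc(Nc2nn(-c3ccc([N+](=O)[O-])cc3)c3nc(Nc4ccccc4)n(-c4ccccc4)c(=O)c23)cc1` gives 30.2% in this assay.

Among the compounds with values here, the only measured step, a number 3.6 percentage points higher from compound 1 to compound 2 (within the scatter), leaves compound 2 and compound 1 within the scatter of each other, so neither is set apart. Compound 3 `O=c1c2c(Nc3ccc(Cl)cc3)nn(-c3ccc([N+](=O)[O-])cc3)c2nc(Nc2ccccc2)n1-c1ccccc1` differs from compound 2 by chloro in place of methyl on an aromatic carbon. Within the data shown here, no measured step concerns a chloro for methyl exchange; the step from compound 1 to compound 2 is a different change and does not bear on it. Resting on compound 2 alone, the step is expected to be a number 1.8 percentage points higher from compound 2 to compound 3 (within the scatter), none beyond the scatter. Compound 3 is therefore estimated at 32%, between 20% and 44%.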

Compound 3, a percentage reported as inhibition, in the whole organism at one dose (the size of the read-out at that dose, not a potency): 20.6%
Compound 3: the middle estimate sits 11.4 percentage points above what was measured; low and high end bracket the measured number.
By their numbers in this assay, from the lowest: compounds 3, 1 and 2 (each within the scatter of the next).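

In this assay, chloro in place of methyl on this aromatic carbon, para to a large group, gives a number 9.6 percentage points lower from compound 2 to compound 3 (within the scatter) and so does not set the two groups apart. (4-Chlorophenyl)amino in place of methylsulfanyl gives a number 6 percentage points lower from compound 1 to compound 3 (within the scatter) and also stays within the scatter, so all three compounds remain inseparable in this read-out. No evidence on hand bears on this result. Still open, going by these compounds, is whether another group at this place, such as a carboxylic acid, an amine or a longer chain, would give a number beyond the scatter.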